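Triazole series: 2-methylphenyl in place of 4-bromophenyl

This account rests on a few compounds, and the source may have more. Where it says the series, first, only, none or still open, it means among the compounds named here.

Three analogues sharing one core have been measured in a functional assay on the whole organism (strain Albino Wistar) for inhibition, with Rattus norvegicus as the target, read by paw edema, with stated times of 1 h and 5 h, at a dose of 10 mg/kg by the oral route; on this read-out lower numbers stand for less inhibition and higher numbers for more inhibition at the one dose given (going by the name of the read-out). Compound 1 `Clc1cccc(-n2cc(CSc3nc4ccccc4s3)nn2)c1` gives 39.6%. Compound 2 `Clc1ccc(-n2cc(CSc3nc4ccccc4s3)nn2)cc1` gives 43.4%. Compound 3 `Brc1ccc(-n2cc(CSc3nc4ccccc4s3)nn2)cc1` gives 59.2%, the highest of the three numbers. Its nearest neighbour is compound 2, the difference being a number 15.8 percentage points higher from compound 2 to compound 3 (beyond the scatter), and the furthest is compound 1, with a number 19.6 percentage points higher from compound 1 to compound 3 (beyond the scatter). Between the two chlorophenyl compounds the change is a number 3.8 percentage points higher from compound 1 to compound 2 (within the scatter).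

Compound 4 `Cc1ccccc1-n1cc(CSc2nc3ccccc3s2)nn1` has not yet been measured. The change from compound 3 is 2-methylphenyl in place of 4-bromophenyl on an aromatic nitrogen. Within the data shown here, no measured step tests a methyl group or a substituent at the 2-position; the only halogen step is the bromo for chloro exchange, which gave a modest gain in this assay, and the two position steps were within or just beyond the scatter. Since the gain of compound 3 over compound 2 came with the bromine, and compound 4 carries no halogen, a drop back toward the chlorophenyl numbers is expected, though with wide uncertainty.

Compound 4 is expected to give 44%, in the range 30% to 58%. The estimated step is therefore a number 15.2 percentage points lower from compound 3 to compound 4 (beyond the scatter), a modest fall.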

Compound 4, a percentage reported as inhibition, in the whole organism at one dose (the size of the read-out at that dose, not a potency): 43.4%
For compound 4 the middle estimate is 0.6 percentage points above the measured one, within the range that was stated.
By their numbers in this assay, from the lowest: compounds 1, 2 and 4 (each within the scatter of the next); then compound 3.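

In this assay, the step to the 2-methylphenyl group is a number 15.8 percentage points lower from compound 3 to compound 4 (beyond the scatter), while the comparisons with the chlorophenyl compounds give no change at the digits printed from compound 2 to compound 4 (within the scatter) and a number 3.8 percentage points higher from compound 1 to compound 4 (within the scatter). On this aromatic nitrogen, a phenyl ring bearing methyl rather than halogen therefore reads level with both chlorophenyl compounds, so a halogen is not required to reach that level, and among the four compounds only the 4-bromophenyl group of compound 3 stands apart. No measurement available here accounts for the separation of compound 3 from the other three.

The compounds shown leave open whether the higher number of compound 3 goes with bromine itself or with the place bromine holds on the ring, since no methyl group in that place and no bromine elsewhere on the ring appears among them. Also open, going by these compounds, is how an amine or a carboxylic acid on this phenyl ring would read in this assay, as all four groups here are carbon-only aromatic rings with a single halogen or methyl substituent.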